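The source may report more compounds than this note shows. Statements on the series, on what has been measured and on what is new or still open speak of the compounds shown alone.

Three compounds of this set have a value in a functional assay on K562 cells (Homo sapiens), read by MTT assay, with a stated time of 72 h; a higher number here means a weaker inhibitor, a lower number a stronger inhibitor. Compound 3 `COc1ncnc2c1c(-c1ccccc1)cn2[C@@H]1O[C@H](CO)[C@@H](O)[C@H]1O` reaches only the limit of the assay, > 20000 nM. Compound 1 `COc1ncnc2c1c(-c1cccs1)cn2[C@@H]1O[C@H](CO)[C@@H](O)[C@H]1O` gives 6200 nM. The change between them, (thiophen-2-yl in place of phenyl on an aromatic carbon), makes the step of an at least 3.2-fold lower number from compound 3 to compound 1 (0.50 log units; beyond the scatter); its size is bounded on one side by the limit of > 20000 nM in this assay, at which 2 of the 3 values shown sit. Compound 2 `Nc1nc(N)c2c(-c3ccccc3)cn([C@@H]3O[C@H](CO)[C@@H](O)[C@H]3O)c2n1` likewise reaches only the limit of the assay, > 20000 nM. The difference between the core of compound 2 and the core of compound 3 is not broken down here. Compound 4 `Nc1nc(N)c2c(-c3cccs3)cn([C@@H]3O[C@H](CO)[C@@H](O)[C@H]3O)c2n1` is not yet measured in this assay. It carries the same change relative to compound 2 as compound 1 does relative to compound 3, namely (thiophen-2-yl in place of phenyl on an aromatic carbon). The step expected from compound 2 to compound 4 is put at an at least 2.2-fold lower number from compound 2 to compound 4 (0.34 log units; beyond the scatter), resting on the measured step of an at least 3.2-fold lower number from compound 3 to compound 1 (0.50 log units; beyond the scatter). Compound 4 is accordingly expected at 9000 nM, within 2500 nM to 40000 nM.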

Compound 4, half-maximal inhibitory concentration: > 20000 nM
Compound 4 was reported as a limit (the forecaster's own chance of this, stated with the estimate: 50%); at least 2.2-fold (0.34 log units) between middle value and limit.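

Compound 2 and compound 4 are both reported only as limits, so no step between them can be read: the limit of > 20000 nM in this assay, at which 3 of the 4 values shown sit.

Going by these compounds, whether thiophen-2-yl in place of phenyl changes the number at all on the core of compound 2 stays open.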